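The compounds below may be only part of what the source reports. "The series", "measured", "known", "first", "only" and "open" are said of these compounds alone.

Compound 1 `CNC(=O)c1cc(Oc2ccc(NC(=O)c3nn(-c4ccc(C)cc4)c(=O)cc3C)cc2F)ccn1` gives 8380 nM in a functional assay on MCF7 cells (Homo sapiens) for cytotoxicity, read by MTT assay, with a stated time of 72 h; a higher number here means a weaker inhibitor, a lower number a stronger inhibitor. Compound 2 `CNC(=O)c1cc(Oc2ccc(NC(=O)c3nn(-c4ccccc4F)c(=O)cc3C)cc2F)ccn1` reaches only the limit of this assay, > 40000 nM. Compound 3 `Cc1cc(=O)n(-c2ccccc2C(F)(F)F)nc1C(=O)Nc1ccc(Oc2ncnc3ccsc23)cc1` gives 5550 nM, the low end of the two numbers, with compound 1 within the scatter of it. Compound 4 `Cc1ccc(-n2nc(C(=O)Nc3ccc(Oc4ncnc5ccsc45)cc3)c(C)cc2=O)cc1` carries the change (4-methylphenyl in place of 2-(trifluoromethyl)phenyl on an aromatic nitrogen). Within the data shown here, the only measured step touching this position is an at least 4.7-fold higher number from compound 1 to compound 2 (0.67 log units; beyond the scatter), where the 4-methylphenyl compound holds the number and its ortho-substituted counterpart runs to the limit of > 40000 nM in this assay, at which 1 of the 3 values shown sits. Read in reverse, that step points toward a lower number once 4-methylphenyl enters. Compound 4 is therefore expected at 2200 nM, between 700 nM and 7000 nM. The step expected from compound 3 to compound 4 is a 2.5-fold lower number from compound 3 to compound 4 (0.40 log units; beyond the scatter).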

Compound 4, half-maximal inhibitory concentration: 23800 nM
The estimate for compound 4 lay 11-fold (1.03 log units) below the measured number; the whole stated range lies below it.
By their numbers in this assay, from the lowest: compounds 3 and 1 (each within the scatter of the next); then compound 4. At a limit, above all of these: compound 2.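

In this assay, the exchange on the aromatic nitrogen gives a 4.3-fold higher number from compound 3 to compound 4 (0.63 log units; beyond the scatter), so 4-methylphenyl is not the better group at this position on the core of compound 3. The direction seen with compound 1 and compound 2 therefore does not carry over to this core. Compound 2 also gives that earlier step no exact size, as its value is a limit: the limit of > 40000 nM in this assay, at which 1 of the 4 values shown sits.

As far as these compounds go, it stays open whether the opposite direction belongs to the core or to the groups compared, 2-fluorophenyl in one pair and 2-(trifluoromethyl)phenyl in the other. From the compounds shown here alone, the effect of an unsubstituted phenyl, or of a phenyl carrying an amine, on either core also stays open.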